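Hydroxy for methyl on the ethyl chain of a tetrazole series

This account rests on a few compounds, and the source may have more. Where it says the series, first, only, none or still open, it means among the compounds named here.

Measured so far:
compound 1, `CCCc1nc(C)nc2c1CCC(=O)N2Cc1ccc(-c2ccccc2-c2nn[nH]n2)cc1`, -86%
compound 2, `CCc1nc(C)c2c(n1)N(Cc1ccc(-c3ccccc3-c3nn[nH]n3)cc1)C(=O)CC2`, -76%

Of the compounds shown here, two have been measured in a functional assay on the whole organism (artery) with Rattus norvegicus as the target, with a stated time of 60 min, at a dose of 3 mg/kg by the intraduodenal route; on this read-out lower numbers stand for less inhibition and higher numbers for more inhibition at the one dose given (going by the name of the read-out). Compound 1 gives -86%. Compound 2 gives -76%; this is the higher of the two numbers, but the gap to compound 1 lies within the scatter, so the two readings cannot be told apart and the inhibition in this assay is to be taken as level between them.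

Compound 3, `Cc1nc(CO)nc2c1CCC(=O)N2Cc1ccc(-c2ccccc2-c2nn[nH]n2)cc1`, has not yet been measured. It differs from compound 2 in one place: hydroxy in place of methyl on a saturated chain carbon bound to an aromatic carbon. Among the measured compounds shown here, no step between two measured compounds bears on this kind of change, so the data give no direct guide to its size or direction.

Both measured compounds sit in the same strongly negative region of this assay . For compound 3 a step of a number 11 percentage points higher from compound 2 to compound 3 (beyond the scatter) is expected, that is, a reading not far from its two predecessors. Compound 3 is therefore estimated at -65%, with a range from -95% to -25%.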

Compound 3, a percentage reported as inhibition, in the whole organism at one dose (the size of the read-out at that dose, not a potency): -30%
Estimate against measurement, compound 3: 35 percentage points below, and the stated range covers the measured number.
By their numbers in this assay, from the lowest: compounds 1 and 2 (each within the scatter of the next); then compound 3.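

In this assay, among the compounds shown here, the exchange of methyl for hydroxy on a saturated chain carbon bound to an aromatic carbon gives a number 46 percentage points higher from compound 2 to compound 3 (beyond the scatter), the first step that can be read at all. It shows that the reading responds strongly at this position: ethyl to hydroxymethyl swaps a single heavy atom and brings in one hydrogen-bond donor and one acceptor, and that alone moves the number by a large amount. Nothing measured here explains the size of this step.

The compounds shown do not tell whether this step is specific to the hydroxy or would also appear with another group at this place, such as a methoxy, an amine or a carboxylic acid. They also leave open how a longer chain carrying the hydroxy at its end would read.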